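Fluoro for methyl on two related quinazolinone cores

A few compounds are considered here, and "the series" means these few. Any claim that something is new, unique, unknown or untested is made for them only; others in the source may bear on it.

Measured compounds:
compound 1 `Cc1ccc2c(=O)[nH]c(-c3ccccc3C)nc2c1`, 39.2%
compound 3 `Cc1ccc2c(=O)[nH]c(-c3ccccc3F)nc2c1`, 0%

Compound 1 `Cc1ccc2c(=O)[nH]c(-c3ccccc3C)nc2c1` and compound 3 `Cc1ccc2c(=O)[nH]c(-c3ccccc3F)nc2c1` were tested in an assay on isolated protein for inhibition of DNA topoisomerase 1 (Homo sapiens), with a stated time of 30 min, tested at 20 uM; on this read-out lower numbers stand for a weaker effect and higher numbers for a stronger effect at the one concentration tested. Compound 1 gives 39.2%, while compound 3 gives 0%. Within the data shown here, the one change between them is fluoro in place of methyl on an aromatic carbon, and it made a step of a number 39.2 percentage points lower from compound 1 to compound 3 (beyond the scatter).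

Compound 2 `Cc1ccc2nc(-c3ccccc3C)[nH]c(=O)c2c1` shares its atoms with compound 1 but joins them differently; the difference between the two cores is not broken down here, and in this assay compound 2 gives "not determined" (no result reported).

Compound 4 `Cc1ccc2nc(-c3ccccc3F)[nH]c(=O)c2c1` stands to compound 2 as compound 3 stands to compound 1: the change is fluoro in place of methyl on an aromatic carbon, the same change at the same place. Because the step of a number 39.2 percentage points lower from compound 1 to compound 3 (beyond the scatter) took the read-out to the floor, a large downward step is expected here as well, though compound 2 itself has no number to step from. Compound 4 is therefore estimated at 5%, between 0% and 30%.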

Compound 4, a percentage reported as inhibition, at one concentration (the size of the read-out at that concentration, not a potency): 36.3%
Compound 4: middle estimate off by 31.3 percentage points, on the low side; the whole stated range lies below it.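

No step can be read from compound 2 to compound 4; compound 2 has no single number to start from. The compounds shown leave open whether fluoro in place of methyl changes the read-out on this core. Nothing shown offers an explanation for the result of compound 4.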